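Amine variation at the chain end: compound 3 to compound 4

The source may hold more compounds than are shown below. What is called first, only, known or untested is meant among the compounds shown, and "the series" means these compounds.

Three compounds of the series have been run in a functional assay on the whole organism with Mus musculus as the target, at a dose of 50 mg/kg by the oral route; on this read-out lower numbers stand for less inhibition and higher numbers for more inhibition at the one dose given (going by the name of the read-out). Compound 1, `CN(C)CCCCOc1ccccc1/C=C/c1cccc(F)c1`, gives 12.5%. Compound 2, `C(=C/c1ccccc1OCCCCN1CCCC1)\c1ccccc1`, gives 87.5%. Among the measured compounds shown here, compound 3, `OC1CCN(CCCCOc2ccccc2/C=C/c2ccccc2)CC1`, gives 50% and so stands second highest of the three numbers, beyond the scatter from compound 1 on the low side and from compound 2 on the high side; only the step from compound 2 to compound 3 is a single change, and it is a number 37.5 percentage points lower from compound 2 to compound 3 (beyond the scatter), a large drop on exchange of the amine at the chain end.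

Compound 4, `CCCN1CCN(CCCCOc2ccccc2/C=C/c2ccccc2)CC1`, differs from compound 3 as follows: 4-propylpiperazin-1-yl in place of 4-hydroxypiperidin-1-yl on a saturated chain carbon, four bonds along the chain from an oxygen on an aromatic ring.

For the measured compounds named here, the only step that bears on this is the one from compound 2 to compound 3, where a ring amine without a hydrogen-bond donor gave the higher number. Compound 4 again carries a ring amine without a hydrogen-bond donor, though a different ring from compound 2, so a rise in this assay is expected rather than a fall. The step is estimated as a number 15 percentage points higher from compound 3 to compound 4 (beyond the scatter), and compound 4 is expected to give 65%, with a range of 35% to 90%.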

Compound 4, a percentage reported as inhibition, in the whole organism at one dose (the size of the read-out at that dose, not a potency): 87.5%
For compound 4 the middle estimate is 22.5 percentage points below the measured one; measured number inside the range.
By their numbers in this assay, from the lowest: compound 1; then compound 3; then compounds 2 and 4 (each within the scatter of the next).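

In this assay, 4-propylpiperazin-1-yl in place of 4-hydroxypiperidin-1-yl on a saturated chain carbon, four bonds along the chain from an oxygen on an aromatic ring, gives a number 37.5 percentage points higher from compound 3 to compound 4 (beyond the scatter), so the drop seen earlier at this place is not a feature of every exchange of pyrrolidin-1-yl. Among the compounds shown here, the comparison with the first amine gives no change at the digits printed from compound 2 to compound 4 (within the scatter), so at this place the read-out at this dose does not separate pyrrolidin-1-yl from 4-propylpiperazin-1-yl, even though the latter has 9 heavy atoms and a second ring hetero atom, while 4-hydroxypiperidin-1-yl, with 1 hydrogen-bond donor against 0 for 4-propylpiperazin-1-yl, stands beyond the scatter from both. No measurement on hand accounts for these differences at the chain end.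

The compounds shown leave open whether the lower number of compound 3 goes with the hydroxyl or with the piperidine ring as a whole, a question that plain piperidin-1-yl at the same place would separate. Also open, on these data alone, is how morpholin-4-yl or 4-methylpiperazin-1-yl would stand at this chain end, on the same unsubstituted core.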